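Hydroxypiperidine Sulfonamide Replacing Morpholine in a Urea Series

The compounds below may be only part of what the source reports. "The series", "measured", "known", "first", "only" and "open" are said of these compounds alone.

Three measured compounds share one core. Compound 1 `O=C(NCc1ccc(S(=O)(=O)C2CCOCC2)cc1)N1Cc2ccncc2C1` gives 26 nM in an assay on isolated protein for inhibition of Nicotinamide phosphoribosyltransferase (Homo sapiens), read by mass spectrometry, with stated times of 15 min and 30 min; on this read-out higher numbers stand for weaker inhibition and lower numbers for stronger inhibition. Compound 2 `CCC(=O)N1CCC(S(=O)(=O)c2ccc(CNC(=O)N3Cc4ccncc4C3)cc2)CC1` gives 27 nM in this assay, and the step of a 1.0-fold higher number from compound 1 to compound 2 (0.02 log units; within the scatter). Compound 3 `O=C(NCc1ccc(S(=O)(=O)N2CCOCC2)cc1)N1Cc2ccncc2C1` gives 71 nM in this assay, the highest number of the three, set by the steps of a 2.7-fold higher number from compound 1 to compound 3 (0.44 log units; beyond the scatter) and a 2.6-fold higher number from compound 2 to compound 3 (0.42 log units; beyond the scatter).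

Compound 4 `O=C(NCc1ccc(S(=O)(=O)N2CCC[C@@H](O)C2)cc1)N1Cc2ccncc2C1` differs from compound 3 in one place: 3-hydroxypiperidin-1-yl in place of morpholin-4-yl on a sulfonyl sulfur. The measured steps only compare morpholin-4-yl with two carbon-linked rings; none compares it with another nitrogen-linked ring, so they bear on this change only loosely. Compound 4 is therefore expected to stay near compound 3. The step of a 1.2-fold lower number from compound 3 to compound 4 (0.07 log units; within the scatter) is expected to lie within the scatter. Compound 4 is estimated at 60 nM, with a range from 25 nM to 150 nM.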

Compound 4, half-maximal inhibitory concentration: 28 nM
The estimate for compound 4 lay 2.1-fold (0.33 log units) above the measured number; the range from low to high includes it.
By their numbers in this assay, from the lowest: compounds 1, 2 and 4 (each within the scatter of the next); then compound 3.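

Linking the ring through nitrogen does not by itself set the higher number of compound 3: 3-hydroxypiperidin-1-yl on the sulfonyl sulfur gives a clear gain (a 2.5-fold lower number from compound 3 to compound 4 (0.40 log units; beyond the scatter)). It also brings this nitrogen-linked ring level with both carbon-linked rings (a 1.1-fold higher number from compound 1 to compound 4 (0.03 log units; within the scatter); a 1.0-fold higher number from compound 2 to compound 4 (0.02 log units; within the scatter)). No measurement here explains this gain.

Plain piperidin-1-yl, without the hydroxyl, would show whether the hydroxyl or the loss of the morpholine ring oxygen matters. From the compounds shown here alone, the mirror-image alcohol of compound 4 also remains open.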